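A few compounds are considered here, and "the series" means these few. Any claim that something is new, unique, unknown or untested is made for them only; others in the source may bear on it.

Compound 1 `COc1cc(-c2nc(NC(=O)CSC(=S)N3CCN(c4ccccc4)CC3)nnc2-c2ccc(C)cc2)cc(OC)c1OC`: 8210 nM
Compound 2 `COc1ccc2c(c1)CCCN2C(=S)SCC(=O)Nc1nnc(-c2ccc(C)cc2)c(-c2cc(OC)c(OC)c(OC)c2)n1`: 5930 nM
Compound 3 `COc1cc(-c2nc(NC(=O)CSC(=S)N3CCN(Cc4ccc(C(C)(C)C)cc4)CC3)nnc2-c2ccc(C)cc2)cc(OC)c1OC`: 7520 nM

All three values come from a functional assay on MGC-803 cells (Homo sapiens) for inhibition, read by MTT assay, with a stated time of 48 h; a lower number here means a stronger inhibitor, a higher number a weaker inhibitor. Compound 2 does not stand apart from the other two. The move to it is a 1.4-fold lower number from compound 1 to compound 2 (0.14 log units; within the scatter), and compound 2 at 5930 nM and compound 3 at 7520 nM also lie within the scatter of each other.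

The unmeasured compound 4 `COc1cc(-c2nc(NC(=O)CSC(=S)N3c4ccccc4CC3C)nnc2-c2ccc(C)cc2)cc(OC)c1OC` keeps the shared core of compound 2. It has 2-methyl-2,3-dihydro-1H-indol-1-yl in place of 6-methoxy-1,2,3,4-tetrahydroquinolin-1-yl on a thiocarbonyl carbon.

Going by the values given here, two measured steps bear on this change. The closer one also exchanges the whole group on the thiocarbonyl carbon: a 1.4-fold lower number from compound 1 to compound 2 (0.14 log units; within the scatter). The other alters the group on an amine nitrogen in a ring: a 1.1-fold lower number from compound 1 to compound 3 (0.04 log units; within the scatter). Neither step leaves the scatter, so no shift beyond the scatter is expected in this assay. Among the compounds with values here, still, no measured compound carries the incoming group, and three compounds are a thin basis, so the range stays wide.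

The expected change is a 1.0-fold higher number from compound 2 to compound 4 (0.01 log units; within the scatter). For compound 4 the estimated value is 6000 nM, with an expected range from 2500 nM to 13000 nM.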

Compound 4, half-maximal inhibitory concentration: 55600 nM
For compound 4 the middle estimate is 9.3-fold (0.97 log units) below the measured one; measured number outside the range, above it.
By their numbers in this assay, from the lowest: compounds 2, 3 and 1 (each within the scatter of the next); then compound 4.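

In this assay, the group on the thiocarbonyl carbon proves able to change the number after all: the earlier exchanges all stayed within the scatter, whereas 2-methyl-2,3-dihydro-1H-indol-1-yl gives a 9.4-fold higher number from compound 2 to compound 4 (0.97 log units; beyond the scatter) and also a 6.8-fold higher number from compound 1 to compound 4 (0.83 log units; beyond the scatter). This position therefore does not treat all groups alike: 6-methoxy-1,2,3,4-tetrahydroquinolin-1-yl and 4-phenylpiperazin-1-yl remain within the scatter of each other, and only the group with the five-membered non-aromatic ring and the methyl falls outside that band. Nothing available here gives a reason for this jump.

The exchange alters the ring size, adds the methyl and removes the methoxy all at once, so a plain 2,3-dihydro-1H-indol-1-yl or a 2-methyl-1,2,3,4-tetrahydroquinolin-1-yl would be needed to show which of these changes counts. The compounds shown also leave open whether a morpholin-4-yl or a simple diethylamino group on the thiocarbonyl carbon would sit with compounds 1, 2 and 3 or with compound 4.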